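Swapping methylsulfanyl for methoxy on the benzyl ring

The source may hold more compounds than are shown below. What is called first, only, known or untested is meant among the compounds shown, and "the series" means these compounds.

In a functional assay on MCF7 cells (Homo sapiens) for cytotoxicity, read by MTT assay, with a stated time of 72 h (a higher number here means a weaker inhibitor of growth, a lower number a stronger inhibitor of growth), compound 2 `CSc1ccc(CNc2nc(SC)nc3ncccc23)cc1` gives 4370 nM and stands at the lowest of the two numbers shown. Compound 1 `CCCCC[Se]c1nc([Se]CCCCC)c2cccnc2n1` gives a higher number in this assay, 67700 nM, a gap beyond the usual scatter. Compound 3 `Sc1nc(NCc2ccccc2)c2ccccc2n1` reaches only a limit of this assay, > 100000 nM, so no number is known for it (the limit of > 100000 nM in this assay, at which 1 of the 3 values shown sits). Compound 4 `COc1ccc(CNc2nc(SC)nc3ncccc23)cc1` has not been measured; it differs from compound 2 by methoxy in place of methylsulfanyl on an aromatic carbon. Within the data shown here, no measured pair shows this change, so no step beyond the scatter is expected in either direction from compound 2 to compound 4, a 1.4-fold higher number from compound 2 to compound 4 (0.14 log units; within the scatter) being the estimate. Compound 4 is therefore expected to give about 6000 nM in this assay, between 2500 nM and 15000 nM.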

Compound 4, concentration for total growth inhibition: > 100000 nM
Compound 4 was reported as a limit; the forecaster's own chance of this, stated with the estimate: 5%; middle value at least 16-fold (1.22 log units) from the limit.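

On an aromatic carbon para to a large group, methoxy in place of methylsulfanyl is far from a neutral swap: in this assay the change gives an at least 22-fold higher number from compound 2 to compound 4 (1.35 log units; beyond the scatter). The two groups match in heavy atoms and hydrogen-bond acceptors, so exchanging sulfur for oxygen at this place is enough to produce that step. The reading of compound 4 is a limit of the assay, not a number: the limit of > 100000 nM in this assay, at which 2 of the 4 values shown sit.

The compounds shown leave open how a chlorine atom, an amine or a longer chain such as ethylsulfanyl would read at this place. They also leave open whether the step holds on another core.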